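From thiophen-2-yl to 2,4-dichlorophenyl

This account rests on a few compounds, and the source may have more. Where it says the series, first, only, none or still open, it means among the compounds named here.

In a functional assay on HeLa cells (Homo sapiens) for inhibition, read by MTT assay, with a stated time of 48 h (a lower number here means a stronger inhibitor, a higher number a weaker inhibitor), compound 1 (`O=C(CC(c1ccccc1)C(C(=O)Nc1ccccn1)C(=O)Nc1ccccn1)c1ccccc1`) gives 28100 nM and compound 2 (`O=C(CC(c1ccc(F)cc1)C(C(=O)Nc1ccccn1)C(=O)Nc1ccccn1)c1ccccc1`) gives 20800 nM. For the measured compounds named here, the one measured step in this small set is a 1.4-fold lower number from compound 1 to compound 2 (0.13 log units; within the scatter), and it involves fluoro in place of hydrogen on an aromatic carbon. Compound 3 (`O=C(CC(c1cccs1)C(C(=O)Nc1ccccn1)C(=O)Nc1ccccn1)c1ccccc1`) stands apart, with its result recorded as "not active" (no number reported), so it offers no number from which a step could be counted.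

Compound 4 (`O=C(CC(c1ccc(Cl)cc1Cl)C(C(=O)Nc1ccccn1)C(=O)Nc1ccccn1)c1ccccc1`) differs from compound 3 by one exchange: 2,4-dichlorophenyl in place of thiophen-2-yl on a saturated chain carbon bound to two saturated chain carbons. It carries 2,4-dichlorophenyl in place of thiophen-2-yl on a saturated chain carbon bound to two saturated chain carbons. Going by the values given here, no measured step covers this exchange, so no step size can be stated from compound 3. The nearest guide is a 1.4-fold lower number from compound 1 to compound 2 (0.13 log units; within the scatter), which stays within the scatter, and so compound 4 is expected to fall in the same region as compound 1 and compound 2, with no clear shift in either direction. Compound 3 also shows that a result without a number remains possible here. For compound 4, the expected value is 20000 nM, with an estimated range of 7000 nM to 50000 nM.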

Compound 4, half-maximal inhibitory concentration: 13500 nM
The estimate for compound 4 lay 1.5-fold (0.17 log units) above the measured number; measured number inside the range.
By their numbers in this assay, from the lowest: compounds 4, 2 and 1 (each within the scatter of the next, the first and the last beyond it).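

For the compounds shown here, on the saturated chain carbon bound to two saturated chain carbons, 2,4-dichlorophenyl in place of phenyl gives the only step at this position that passes the scatter (a 2.1-fold lower number from compound 1 to compound 4 (0.32 log units; beyond the scatter)), and it is a modest one, while 2,4-dichlorophenyl in place of 4-fluorophenyl stays within it (a 1.5-fold lower number from compound 2 to compound 4 (0.19 log units; within the scatter)) in this assay. The step from compound 3 to compound 4 cannot be read, as compound 3 has no number, but the two results show that this exchange separates a compound recorded as not active from one with a measured value, so the group at this position can decide whether a number is obtained at all. Nothing measured here explains either the modest step or the result for compound 3.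

The compounds shown leave open whether both chlorine atoms of compound 4 are needed, since neither 2-chlorophenyl nor 4-chlorophenyl stands among them to separate the two. They also leave open whether the result for compound 3 extends to other five-membered aromatic rings such as furan-2-yl, and how a group carrying an amine or a carboxylic acid would behave at this position.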